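The compounds below may be only part of what the source reports. "The series", "measured", "known", "first", "only" and "open" are said of these compounds alone.

Measured compounds:
Compound 1 `O=C1[C@@H](NS(=O)(=O)c2ccc(-c3ccc(Cl)s3)s2)CCN1Cc1cc2[nH]cccc-2n1` gives 42% in an assay on isolated protein for inhibition of coagulation factor X (Oryctolagus cuniculus), tested at 1 uM; a higher number here means more inhibition at the concentration tested (going by the name of the read-out), a lower number less inhibition.
Compound 2 `O=C1[C@@H](NS(=O)(=O)c2cc3ncccc3s2)CCN1Cc1cc2c[nH]ccc-2n1` gives 61% in this assay.

Compound 1 stands at the lower of the two numbers on record; its nearest neighbour, compound 2, lies higher by an amount that exceeds the usual scatter of such measurements. The two compounds differ in more than one place, so their gap is reported only as what the two values show, not as a step.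

The unmeasured compound 3 `O=C1[C@@H](NS(=O)(=O)c2ccc(-c3ccon3)s2)CCN1Cc1cc2[nH]cccc-2n1` follows from compound 1 by a single change: 1,2-oxazol-3-yl in place of 5-chlorothiophen-2-yl on an aromatic carbon. A five-membered aromatic ring with one hetero atom and a chlorine leaves, and a five-membered aromatic ring with two hetero atoms and one more hydrogen-bond acceptor enters.

For the measured compounds named here, no step between measured compounds covers this kind of change, so no measured comparison is available to calibrate it. The account therefore expects a fall in this assay from compound 1 to compound 3 of a size beyond the scatter, a number 27 percentage points lower from compound 1 to compound 3 (beyond the scatter). For compound 3 the estimate in this assay is 15%, with a range from 0% to 38%.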

Compound 3, a percentage reported as inhibition, at one concentration (the size of the read-out at that concentration, not a potency): 31%
The estimate for compound 3 lay 16 percentage points below the measured number, within the range that was stated.
By their numbers in this assay, from the lowest: compound 3; then compound 1; then compound 2.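

For the compounds shown here, this is the first step read at this position, on an aromatic carbon next to the ring sulfur of the five-membered aromatic ring: in this assay, 1,2-oxazol-3-yl in place of 5-chlorothiophen-2-yl gives a number 11 percentage points lower from compound 1 to compound 3 (beyond the scatter), a modest fall that lies beyond the scatter. The chlorine and the sulfur of the group that leaves are therefore not required for a readable result, since compound 3 still gives 31% at the concentration tested. No measurement offered here explains the fall.

The change replaces the whole group, so the compounds shown do not separate the loss of the chlorine from the exchange of one ring for the other, and a plain thiophen-2-yl group at the same place would be needed to part the two. They also leave open how this position responds to groups of a different kind, such as a 4-chlorophenyl ring, an aminomethyl group or a carboxylic acid, and whether the fall seen here would recur on another core.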